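Tolerated concentrations on the shared core: toward compound 4

The source may report more compounds than this note shows. Statements on the series, on what has been measured and on what is new or still open speak of the compounds shown alone.

Measured so far:
compound 1, `CS(=O)(=O)Nc1ccc2c(c1)S(=O)(=O)N=C(C1=C(O)C3CCCC3N(CCC3CC3)C1=O)N2`, > 33000 nM
compound 2, `CS(=O)(=O)Nc1ccc2c(c1)S(=O)(=O)N=C(C1=C(O)[C@H]3CCC[C@H]3N(Cc3ccc(F)c(F)c3)C1=O)N2`, > 1000 nM
compound 3, `CS(=O)(=O)Nc1ccc2c(c1)S(=O)(=O)N=C(C1=C(O)[C@H]3CCC[C@H]3N(Cc3ccc(C(F)(F)F)cc3)C1=O)N2`, > 33000 nM

In an ADME assay on Huh-7 cells (Homo sapiens) for cytotoxicity, with a stated time of 72 h (a higher number here means that more compound is tolerated, a lower number that less compound is tolerated), compound 1 gives > 33000 nM, which is a limit of the assay and not a number. Compound 2 gives > 1000 nM, again a limit. Compound 3 gives > 33000 nM, also a limit. Among the measured compounds shown here, two of the three values sit at the limit of > 33000 nM in this assay, at which 2 of the 3 values shown sit, and one at the limit of > 1000 nM in this assay, at which 1 of the 3 values shown sits, so no compound in this set has a read number, and compound 1 stands at the higher of the two limits.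

For the measured compounds named here, only one step between measured compounds changes a single place: a step that the two limits leave unreadable from compound 2 to compound 3. Both ends are limits, so its size cannot be read, and it gives no measured direction for changes at that place.

Compound 4, `CS(=O)(=O)Nc1ccc2c(c1)S(=O)(=O)N=C(C1=C(O)C3CCCC3N(Cc3ccccc3)C1=O)N2`, differs from compound 1 by phenyl in place of cyclopropylmethyl on a saturated chain carbon bound to an amide-type nitrogen in a ring. The change sits at the same place as the step from compound 2 to compound 3, which is unreadable. With no readable step on record, no step beyond the scatter is expected from compound 1 to compound 4 in this assay. Compound 4 is therefore expected to give 33000 nM, in a range of 10000 nM to 100000 nM. The expected step of a number no higher from compound 1 to compound 4 (the limit leaves the size open) is estimated as near none, and the value is most likely to be returned only as a limit again.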

Compound 4, half-maximal cytotoxic concentration: > 33000 nM
Compound 4 ended at the assay's limit; the forecaster's own chance of this, stated with the estimate: 75%; the middle value lies on the limit itself.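

Compound 1 and compound 4 both stand only as limits in this assay, and the step between them cannot be read. The compounds shown leave open where any of them would give a read number on the shared core, and whether a change of group on a saturated chain carbon bound to an amide-type nitrogen in a ring shifts that number.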